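This account rests on a few compounds, and the source may have more. Where it says the series, first, only, none or still open, it means among the compounds named here.

Three compounds share one core and differ only in the group attached to a saturated ring carbon. Compound 1 `CS(=O)(=O)NC1CCC(CN2CCN(c3cc(=O)c4cc(C(F)(F)F)cc([N+](=O)[O-])c4s3)CC2)CC1` carries a methanesulfonamido group there, and in an ADME assay on Vero cells (Chlorocebus sabaeus) for cytotoxicity, read by MTT assay, with a stated time of 48 h (on this read-out lower numbers stand for stronger inhibition and higher numbers for weaker inhibition), compound 1 gives 48.5 ug/mL. Compound 2 `COc1ccc(C(=O)OC2CCC(CN3CCN(c4cc(=O)c5cc(C(F)(F)F)cc([N+](=O)[O-])c5s4)CC3)CC2)cc1` carries a ((4-methoxyphenyl)carbonyl)oxy group in that place. In this assay compound 2 gives > 64 ug/mL, which is a limit of the assay and not a number. Compound 3 `Cc1cccc(C(=O)OC2CCC(CN3CCN(c4cc(=O)c5cc(C(F)(F)F)cc([N+](=O)[O-])c5s4)CC3)CC2)c1` carries a ((3-methylphenyl)carbonyl)oxy group. In this assay compound 3 gives > 64 ug/mL, again a limit of the assay rather than a number, (the limit of > 64 ug/mL in this assay, at which 2 of the 3 values shown sit). The measured steps read an at least 1.3-fold higher number from compound 1 to compound 2 (0.12 log units; that floor lies within the scatter) and an at least 1.3-fold higher number from compound 1 to compound 3 (0.12 log units; that floor lies within the scatter), while a step that the two limits leave unreadable from compound 2 to compound 3.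

Compound 4 `O=C(OC1CCC(CN2CCN(c3cc(=O)c4cc(C(F)(F)F)cc([N+](=O)[O-])c4s3)CC2)CC1)c1cccc(F)c1` differs from compound 3 in one place: fluoro in place of methyl on an aromatic carbon. The steps that touch this part of the molecule are either within the scatter or unreadable, so no change beyond the scatter is expected in this assay, and the expected step is a step that the limit leaves unreadable from compound 3 to compound 4. Compound 4 is therefore estimated at about 80 ug/mL, within a range from 40 ug/mL to 160 ug/mL, quite possibly reported again only as a limit.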

Compound 4, half-maximal inhibitory concentration: > 64 ug/mL
Compound 4: no number, only a limit; the forecaster's own chance of this, stated with the estimate: 70%; the middle value is on the limit's open side.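

Fluoro in place of methyl on the aromatic carbon leaves compound 4 at a limit of this assay, so a third ester now gives no number: the limit of > 64 ug/mL in this assay, at which 3 of the 4 values shown sit.

Set against the methanesulfonamido group of compound 1, the ((3-fluorophenyl)carbonyl)oxy group gives an at least 1.3-fold higher number from compound 1 to compound 4 (0.12 log units; that floor lies within the scatter), so this comparison, like those for compound 2 and compound 3, does not establish a change beyond the scatter. The steps linking compound 4 to compound 2 and compound 3 cannot be read, as each has a limit at both ends, so neither methyl nor fluoro at this position can be ranked.

Going by these compounds, how far these three esters lie past the limit stays open. An amine or a carboxylic acid on the same aromatic carbon could show whether any group there brings the result back to a measurable number.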